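Bromine to iodine on the phenoxy ring: expected potency

The source may report more compounds than this note shows. Statements on the series, on what has been measured and on what is new or still open speak of the compounds shown alone.

compound 1 `Cc1nn(C)c(Oc2cccc(F)c2)c1/C=N\CCCCCCOc1cc2oc(=O)cc(C)c2cc1Cl`: > 25000 nM (a limit)
compound 2 `Cc1nn(C)c(Oc2ccc(Br)cc2)c1/C=N\CCCCCCOc1cc2oc(=O)cc(C)c2cc1Cl`: 5420 nM

In a functional assay on U-87MG ATCC cells for antiproliferative activity against U-87 MG (Homo sapiens), read by MTT assay, with a stated time of 72 h (a lower number here means a stronger inhibitor, a higher number a weaker inhibitor), compound 1 shows > 25000 nM, which is a limit of the assay and not a number. In this assay, going by the values given here, compound 2 gives 5420 nM, the one real number in hand, so compound 2 stands alone among the measured values. From the compounds shown here alone, the single measured move, an at least 4.6-fold lower number from compound 1 to compound 2 (0.66 log units; beyond the scatter), has one end sitting at the limit of > 25000 nM in this assay, at which 1 of the 2 values shown sits, so its true size is unknown. Compound 3 `Cc1nn(C)c(Oc2ccc(I)cc2)c1/C=N\CCCCCCOc1cc2oc(=O)cc(C)c2cc1Cl` changes (iodo in place of bromo on an aromatic carbon). Among the compounds with values here, no measured step swaps one halogen for another at this place, and no step beyond the scatter is expected. The number expected for compound 3 is 4000 nM, with a range from 1500 nM to 12000 nM. That expected step reads a 1.4-fold lower number from compound 2 to compound 3 (0.13 log units; within the scatter).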

Compound 3, half-maximal inhibitory concentration: 16800 nM
Compound 3: middle estimate off by 4.2-fold (0.62 log units), on the low side; the whole stated range lies below it.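

In this assay, iodo in place of bromo gives a 3.1-fold higher number from compound 2 to compound 3 (0.49 log units; beyond the scatter), so a swap of one halogen for another on this aromatic carbon is enough to change the number. Bromo and iodo are therefore not interchangeable here, and compound 2 holds the lower number of the pair. The other new step, an at least 1.4-fold lower number from compound 1 to compound 3 (0.17 log units; that floor lies within the scatter), cannot be read for its true size: the limit of > 25000 nM in this assay, at which 1 of the 3 values shown sits.

From the compounds shown here alone, what a chloro or methoxy group would do on this same carbon stays open. So does whether the gap between bromo and iodo survives with a shorter chain.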